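This account rests on a few compounds, and the source may have more. Where it says the series, first, only, none or still open, it means among the compounds named here.

In a functional assay on HT-1080 cells (Homo sapiens) for cytotoxicity, read by MTT assay, with a stated time of 72 h (a lower number here means a stronger inhibitor, a higher number a weaker inhibitor), three compounds built on a shared core have been measured: compound 1 `COc1ccc(/C=C2\CCC/C(=C\c3ccccc3Cl)C2=O)cc1OC` gives 6800 nM, compound 2 `COc1ccc(/C=C2\CCC/C(=C\c3cccc(Cl)c3)C2=O)cc1OC` gives 4900 nM and compound 3 `COc1ccc(/C=C2\CCC/C(=C\c3cccc(O)c3)C2=O)cc1OC` gives 1700 nM. Compound 3 has the lowest number of the three, and its gaps to both of the others lie beyond the scatter, so it is the most potent of this small set.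

The next compound, compound 4 `COc1ccc(/C=C2\CCC/C(=C\c3ccc(Cl)c(Cl)c3)C2=O)cc1OC`, has not yet been measured. The change from compound 3 is 3,4-dichlorophenyl in place of 3-hydroxyphenyl on a double-bonded chain carbon bound to a double-bonded ring carbon, with the new group sitting on a double-bonded chain carbon bound to a double-bonded ring carbon.

The closest guide is a 2.9-fold lower number from compound 2 to compound 3 (0.46 log units; beyond the scatter), where hydroxy replaced chloro on an aromatic carbon. Compound 4 reverses that kind of swap, since it has chloro and no hydroxy. The step of a 4.0-fold lower number from compound 1 to compound 3 (0.60 log units; beyond the scatter) points the same way. By contrast, a 1.4-fold lower number from compound 1 to compound 2 (0.14 log units; within the scatter) shows no clear effect of where the single chloro sits. Within the data shown here, no measured compound carries the 3,4-dichlorophenyl group, so its exact effect cannot be read from these data.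

A modest rise is therefore expected in this assay, and the estimated change is a 2.4-fold higher number from compound 3 to compound 4 (0.37 log units; beyond the scatter). Compound 4 is expected to give about 4000 nM, with an estimated range of 1800 nM to 9000 nM.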

Compound 4, half-maximal inhibitory concentration: 3100 nM
Compound 4: middle estimate off by 1.3-fold (0.11 log units), on the high side, within the range that was stated.
By their numbers in this assay, from the lowest: compounds 3, 4, 2 and 1 (each within the scatter of the next, the first and the last beyond it).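

At this position, on a double-bonded chain carbon bound to a double-bonded ring carbon, the new result shows that a ring with no hydrogen-bond donor can still fall within the scatter of the hydroxy compound in this assay (a 1.8-fold higher number from compound 3 to compound 4 (0.26 log units; within the scatter)), so a hydroxy group is not essential for activity near that of compound 3 in this small set. The added chloro gives no clear change from the single-chloro compound (a 1.6-fold lower number from compound 2 to compound 4 (0.20 log units; within the scatter), again within the scatter), while the 3,4-dichlorophenyl group does separate modestly from the 2-chlorophenyl group (a 2.2-fold lower number from compound 1 to compound 4 (0.34 log units; beyond the scatter), beyond the scatter), and this last step changes both the number of chloro groups and where they sit, so it cannot be credited to either alone. Nothing available here explains these differences between the compounds.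

These four compounds leave open whether other groups at this position, such as an amine or a carboxylic acid on the phenyl ring, would fall closer to compound 3 or further from it. They also leave open how much of the remaining spread is real, since most neighbouring gaps lie within the scatter.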